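The compounds below may be only part of what the source reports. "The series", "measured", "known", "first", "only" and "open" are said of these compounds alone.

Measured so far, in an ADME assay on MRC5 cells (Homo sapiens) for cytotoxicity, read by MTT assay, with a stated time of 72 h; a higher number here means a weaker inhibitor of growth, a lower number a stronger inhibitor of growth:

compound 1, `COc1cc(OC)c(/C=C/S(=O)(=O)Cc2ccc(OC)c(N)c2)c(OC)c1`: 80 nM
compound 2, `COc1ccc(CS(=O)(=O)CC(=O)Nc2c(C)cc(C)cc2C)cc1[N+](=O)[O-]`: 28000 nM
compound 3, `COc1cc(/C=C/S(=O)(=O)Cc2ccc(OC)c([N+](=O)[O-])c2)cc(OC)c1`: a limit, > 30000 nM

Compound 2 holds the highest of the two numbers shown in this assay; the nearest number, that of compound 1, lies far lower, beyond the usual scatter. For compound 3 the assay reports no number, only (the limit of > 30000 nM in this assay, at which 1 of the 3 values shown sits). For the measured compounds named here, compound 2 and compound 3 both carry a nitro group on the ring that bears the methoxy group; compound 1 carries an amino group in that place, but it also differs from compound 3 elsewhere, so the two values are recorded side by side and no step between them is computed.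

Compound 4, `COc1ccc(CS(=O)(=O)CC(=O)Nc2c(C)cc(C)cc2C)cc1N`, is still to be measured in this assay. It differs from compound 2 in one place only: amino in place of nitro on an aromatic carbon. Going by the values given here, no measured pair isolates this change. Among the compounds with values here, the step from compound 2 to compound 4 is nevertheless expected to run downward and to exceed the scatter, a 9.3-fold lower number from compound 2 to compound 4 (0.97 log units; beyond the scatter), since compound 1, the only amino compound measured, gives 80 nM. Compound 4 is accordingly estimated at 3000 nM, with a wide range from 300 nM to 20000 nM.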

Compound 4, concentration for 50% growth inhibition: > 30000 nM
Compound 4 ended at the assay's limit; the forecaster's own chance of this, stated with the estimate: 10%; middle value at least 10-fold (1.00 log units) from the limit.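

In this assay the change reads an at least 1.0-fold higher number from compound 2 to compound 4 (0.02 log units; that floor lies within the scatter), so amino in place of nitro on this aromatic carbon, ortho to a methoxy group, gives no detectable fall in the number on the core of compound 2. Compound 4 reports a limit and not a number: the limit of > 30000 nM in this assay, at which 2 of the 4 values shown sit. An amino group at this place is therefore not enough on its own to bring this core down to a number like that of compound 1, 80 nM, and the low number of compound 1 cannot be assigned to the amino group, as that compound also differs from compound 4 elsewhere.

Still open, on these data alone, is how far the true number of compound 4 lies from that of compound 2, and whether amino in place of nitro would read differently on the core of compound 3. Also open, as far as these compounds go, is whether a hydroxyl group or a carboxylic acid on this aromatic carbon would move the core of compound 2 at all in this assay.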